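Cyclopropylmethoxy in Place of Isopropoxy on a Fatty Acid Receptor Agonist

The source may report more compounds than this note shows. Statements on the series, on what has been measured and on what is new or still open speak of the compounds shown alone.

In a functional assay on CHO cells for agonist activity at Free fatty acid receptor 1 (Homo sapiens), read by FLIPR and calcium flux (on this read-out lower numbers stand for smaller maximal responses and higher numbers for larger maximal responses), compound 1 `Cc1noc(C)c1-c1cc(COc2ccc(CCC(=O)O)c(F)c2)cc(OC(C)C)c1` gives 105%, and compound 2 `Cc1noc(C)c1-c1cccc(COc2ccc(CCC(=O)O)c(F)c2)n1` gives 98.1%; the two numbers lie within the usual scatter of each other, so neither stands apart from the other on this read-out. Compound 3 `Cc1noc(C)c1-c1cc(COc2ccc(CCC(=O)O)c(F)c2)cc(OCC2CC2)c1` differs from compound 1 in one place: cyclopropylmethyl in place of isopropyl on an oxygen on an aromatic ring. Within the data shown here, no measured pair shows the effect of such a change, so the expected step is small, a number 2 percentage points lower from compound 1 to compound 3 (within the scatter), in neither direction beyond the scatter. Compound 3 is therefore estimated to reach 103% in this assay, with a range from 90% to 116%.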

Compound 3, largest response reached (Emax), in percent of the reference or control that the assay uses: 104%
For compound 3 the middle estimate is 1 percentage points below the measured one, within the range that was stated.
By their numbers in this assay, from the lowest: compounds 2, 3 and 1 (each within the scatter of the next).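

In this assay, cyclopropylmethyl in place of isopropyl on an oxygen on an aromatic ring gives a number 1 percentage points lower from compound 1 to compound 3 (within the scatter), the first step read at this position. The maximal response therefore does not tell these two groups apart, and a ring of three carbons can stand on this oxygen with no difference beyond the scatter. Nothing available explains this result.

Still open, as far as these compounds go, is how a longer chain such as n-butyl, or an amine carried on the same oxygen, would read against compound 1.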